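The source may report more compounds than this note shows. Statements on the series, on what has been measured and on what is new or still open speak of the compounds shown alone.

Working notes on the series. In a functional assay on CHO cells for agonist activity at 5-hydroxytryptamine receptor 4 (Homo sapiens), read by a luciferase reporter and cAMP accumulation, with a stated time of 4 h (on this read-out higher numbers stand for an effect only at larger amounts of compound and lower numbers for an effect already at smaller amounts), compound 1 `CC(C)c1nc(C(=O)NC2CCN(CC(C)(C)O)CC2)c2ccccn12` gives 40 nM and compound 3 `CC(C)c1nc(C(=O)NC[C@@H]2[C@H]3CN(CC4CCC4)C[C@@H]23)c2ccccn12` gives 13.2 nM, the lower of the two numbers, with compound 1 standing beyond the scatter above it. Compound 2 `COCCCN1CC2C(C1)C2NC(=O)c1nc(C(C)C)n2ccccc12` gives only a limit in this assay, > 10000 nM, and not a number. No pair among these three differs in a single place, so no measured step is available. Compound 4 `CC(C)c1nc(C(=O)NC[C@@H]2[C@H]3CN(C4CCOCC4)C[C@@H]23)c2ccccn12` differs from compound 3 by oxan-4-yl in place of cyclobutylmethyl on an amine nitrogen in a ring. The expected step is a 2.7-fold higher number from compound 3 to compound 4 (0.42 log units; beyond the scatter), a loss beyond the scatter but not to a limit. Compound 4 is therefore estimated at 35 nM in this assay, within 9 nM to 150 nM.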

Compound 4, half-maximal effective concentration: 20.7 nM
Compound 4: middle estimate off by 1.7-fold (0.23 log units), on the high side; the measured number falls inside the stated range.
By their numbers in this assay, from the lowest: compounds 3, 4 and 1 (each within the scatter of the next, the first and the last beyond it). At a limit, above all of these: compound 2.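

In this assay oxan-4-yl in place of cyclobutylmethyl on an amine nitrogen in a ring reads as (a 1.6-fold higher number from compound 3 to compound 4 (0.20 log units; within the scatter)), so this read-out does not tell the two groups apart at this position, although oxan-4-yl carries a hydrogen-bond acceptor and cyclobutylmethyl none. Nothing at hand bears on a cause for this step. As far as these compounds go, whether a longer chain ending in a carboxylic acid or a primary amine on this nitrogen would stay in the same range remains open, as does the outcome of the same exchange on another core.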